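Naphthalenyl for Phenyl on a Hydantoin Hydroxamate

A few compounds are considered here, and "the series" means these few. Any claim that something is new, unique, unknown or untested is made for them only; others in the source may bear on it.

Measured compounds:
compound 1, `O=C(NO)c1ccc(CN2C(=O)CN(Cc3ccc(Cl)cc3)C2=O)cc1`: 8.3 nM
compound 2, `O=C(NO)c1ccc(CN2C(=O)NC(Cc3ccccc3)(c3ccccc3)C2=O)cc1`: 71.9 nM

Of the compounds shown here, two have been measured in an assay on isolated protein for inhibition of protein deacetylase HDAC6 (Homo sapiens), read by fluorescence, with stated times of 10 min and 2 h; on this read-out lower numbers stand for stronger inhibition and higher numbers for weaker inhibition. Compound 1 gives 8.3 nM in this assay. Compound 2 gives 71.9 nM in this assay, the higher of the two numbers, and its gap to compound 1 lies beyond the scatter of repeated measurements. Within the data shown here, no single-site step connects these two, so their relation is read only from the two values.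

Compound 3, `O=C(NO)c1ccc(CN2C(=O)NC(Cc3cccc4ccccc34)(c3ccccc3)C2=O)cc1`, has not yet been measured. It differs from compound 2 in one place: naphthalen-1-yl in place of phenyl on a saturated chain carbon bound to a saturated ring carbon. Among the measured compounds shown here, no measured pair shows what such a change does on this core, so the expectation rests on compound 2 alone. The author expects the step from compound 2 to compound 3 to be small, a 1.6-fold lower number from compound 2 to compound 3 (0.20 log units; within the scatter), and not certainly beyond the scatter. For compound 3 the estimated value in this assay is 45 nM, with a range from 12 nM to 160 nM.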

Compound 3, half-maximal inhibitory concentration: 91.9 nM
The estimate for compound 3 lay 2.0-fold (0.31 log units) below the measured number; low and high end bracket the measured number.
By their numbers in this assay, from the lowest: compound 1; then compounds 2 and 3 (each within the scatter of the next).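

In this assay, among these compounds, naphthalen-1-yl in place of phenyl on a saturated chain carbon bound to a saturated ring carbon gives a 1.3-fold higher number from compound 2 to compound 3 (0.11 log units; within the scatter), the first single-site step. At this position on the shared core, a second six-membered aromatic ring of carbon only therefore produces no change that can be told apart from the scatter, which the two earlier values alone could not show. No measurement shown speaks to the reason for this result.

The compounds shown leave open how this position would respond to a group of another kind, such as an amine or a carboxylic acid on the aromatic ring, or to a longer chain in place of the benzyl. They also leave open whether benzyl to (naphthalen-1-yl)methyl would give a similar step on the core of compound 1.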